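This account rests on a few compounds, and the source may have more. Where it says the series, first, only, none or still open, it means among the compounds named here.

Measured compounds:
- compound 1, `CC[C@@H](C)[C@H](NC(=O)c1ccc(C(CC)(CC)c2ccc(OCC(O)C(C)(C)C)c(C)c2)n1CC)C(=O)OC`: 26 nM
- compound 2, `CCn1c(C(=O)N(C)c2ccccc2)ccc1C(CC)(CC)c1ccc(OCC(O)C(C)(C)C)c(C)c1`: 6400 nM
- compound 3, `CCn1c(C(=O)N(CCC#N)CCC#N)ccc1C(CC)(CC)c1ccc(OCC(O)C(C)(C)C)c(C)c1`: 97 nM

In an assay on HL-60 cells for agonist activity at vitamin D3 receptor (Homo sapiens), read by microscopy, with a stated time of 96 h (on this read-out lower numbers stand for an effect already at smaller amounts and higher numbers for an effect only at larger amounts of compound), compound 3 gives 97 nM and stands second highest of the three numbers. Compound 1 sits closest, with a 3.7-fold higher number from compound 1 to compound 3 (0.57 log units; beyond the scatter) separating them, while compound 2 is furthest away: a 66-fold lower number from compound 2 to compound 3 (1.82 log units; beyond the scatter).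

Compound 4, `CCn1c(C(=O)Nc2cccc(C(F)(F)F)c2)ccc1C(CC)(CC)c1ccc(OCC(O)C(C)(C)C)c(C)c1`, differs from compound 3 in one place: a group of 11 heavy atoms (7 carbon, 1 nitrogen, 3 fluorine; one six-membered aromatic ring of carbon only) in place of a group of 9 heavy atoms (6 carbon, 3 nitrogen; no ring), on a carbonyl carbon. Among the measured compounds shown here, the step that bears on this most directly is the one from compound 2 to compound 3, where the nitrile-bearing chain took the place of a methyl(phenyl)amino group and the number fell by a large margin (a 66-fold lower number from compound 2 to compound 3 (1.82 log units; beyond the scatter)). Compound 4 moves back toward an aromatic amide, though one that keeps its amide hydrogen and carries a trifluoromethyl group, neither of which compound 2 has, so the size of the return is uncertain. A large rise in the number is nevertheless expected, a 12-fold higher number from compound 3 to compound 4 (1.09 log units; beyond the scatter). Compound 4 is therefore estimated at 1200 nM, in a range from 150 nM to 8000 nM.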

Compound 4, half-maximal effective concentration: > 50000 nM
Compound 4: a limit, no number (the forecaster's own chance of this, stated with the estimate: 10%); at least 41-fold (1.61 log units) between middle value and limit.
By their numbers in this assay, from the lowest: compound 1; then compound 3; then compound 2. At a limit, above all of these: compound 4.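

In this assay compound 4 gives a limit of the assay and not a number: the limit of > 50000 nM in this assay, at which 1 of the 4 values shown sits. On this carbonyl carbon, (3-(trifluoromethyl)phenyl)amino falls far behind both the nitrile-bearing group, with an at least 510-fold higher number from compound 3 to compound 4 (2.71 log units; beyond the scatter), and the (1-(methoxycarbonyl)-2-methylbutyl)amino group, with an at least 1900-fold higher number from compound 1 to compound 4 (3.28 log units; beyond the scatter). It also falls behind the other aromatic amide, with an at least 7.8-fold higher number from compound 2 to compound 4 (0.89 log units; beyond the scatter), so the two compounds with an aromatic ring on the amide nitrogen now hold the two highest positions, and the amide hydrogen, present in both compound 1 and compound 4, does not by itself give a low number.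

From the compounds shown here alone, it remains open whether the trifluoromethyl group or the aromatic ring itself goes with this rise. A plain phenylamino group or a cyclohexylamino group on this carbonyl carbon would help separate the two.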